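Capping the Hydroxy Group of Compound 3 with Acetyl

This account rests on a few compounds, and the source may have more. Where it says the series, first, only, none or still open, it means among the compounds named here.

In a functional assay on HL-60 cells (Homo sapiens) for antiproliferative activity, read by XTT assay, with a stated time of 72 h (on this read-out lower numbers stand for stronger inhibition and higher numbers for weaker inhibition), compound 1 `C=C(C)CCC[C@]1(C)C2=CCC[C@](C)(C[C@H](O)c3ccoc3)[C@H]2CC[C@H]1C` gives 31200 nM, compound 2 `C=C(C)CC[C@]1(C)C2=CCC[C@](C)(C[C@H](O)C3=CC(=O)OC3O)[C@H]2CC[C@H]1C` gives 3200 nM, and compound 3 `C=C(C)CCC[C@]1(C)C2=CCC[C@](C)(C[C@H](O)C3=CC(=O)OC3O)[C@H]2CC[C@H]1C` gives 3000 nM. Compound 3 carries the lowest number of the three, yet its gap to compound 2 lies within the scatter, as a 1.1-fold lower number from compound 2 to compound 3 (0.03 log units; within the scatter) shows; against compound 1 the step of a 10-fold lower number from compound 1 to compound 3 (1.02 log units; beyond the scatter) is large. Compound 4 `C=C(C)CCC[C@]1(C)C2=CCC[C@](C)(C[C@H](OC(C)=O)C3=CC(=O)OC3O)[C@H]2CC[C@H]1C` differs from compound 3 by acetyl in place of hydrogen on an oxygen on a saturated carbon. Among the measured compounds shown here, neither measured step touches this oxygen: one exchanges a ring group, the other a chain group, so no measured step bears on the change, and its direction is unknown. Compound 4 is therefore expected to give about 3000 nM, within 1000 nM to 10000 nM. The expected step of no change at the digits printed from compound 3 to compound 4 (within the scatter) is thus none beyond the scatter.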

Compound 4, half-maximal inhibitory concentration: 3000 nM
Beside the measured number, compound 4's estimate shows no gap at the digits printed, within the range that was stated.
By their numbers in this assay, from the lowest: compounds 3, 4 and 2 (each within the scatter of the next); then compound 1.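

In this assay, among the compounds shown here, the step of no change at the digits printed from compound 3 to compound 4 (within the scatter) gives the first reading at this oxygen, since the earlier steps changed other places. Going from hydroxy to acetoxy, with acetyl in place of hydrogen, gives a step within the scatter, so this one pair shows that a free hydroxy here is not required for the number seen. No measurement shown explains this result. As far as these compounds go, whether this oxygen accepts other groups remains open: a longer chain such as hexanoyl, or an amine in place of the hydroxy, could give a different number.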